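A few compounds are considered here, and "the series" means these few. Any claim that something is new, unique, unknown or untested is made for them only; others in the source may bear on it.

Compound 1 `COc1ccccc1-n1nc(C2CC(C)(C)OC(C)(C)C2)cc1-c1ccc(Cl)cc1`: 1 nM
Compound 2 `COc1ccccc1-n1nc([C@@H]2CCO[C@@H](C(C)C)C2)cc1-c1ccc(Cl)cc1`: 20 nM
Compound 3 `COc1ccccc1-n1nc(C2=CC(C)(C)OC(C)(C)C2)cc1-c1ccc(Cl)cc1`: 3 nM

In an assay on HEK293 cells for inhibition of Voltage-dependent N-type calcium channel subunit alpha-1B (Homo sapiens), read by fluorescence and calcium flux, with a stated time of 5 min (on this read-out higher numbers stand for weaker inhibition and lower numbers for stronger inhibition), compound 1 gives the lowest number of the three. The nearest step is a 3.0-fold higher number from compound 1 to compound 3 (0.48 log units; beyond the scatter), and the furthest is a 20-fold higher number from compound 1 to compound 2 (1.30 log units; beyond the scatter). Compound 4 `COc1ccccc1-n1nc(C2CC(C)(C)OC(C)(C)C2)cc1-c1ccc(C#N)cc1` differs from compound 1 by cyano in place of chloro on an aromatic carbon. Among the measured compounds shown here, none of the measured steps touches this part of the molecule: each of them alters the saturated oxygen-containing ring on the shared core, so no measured step bears directly on the change to compound 4. For the measured compounds named here, with no direct precedent, the expectation is for a step of at most modest size, more likely toward a higher number, namely a 3.0-fold higher number from compound 1 to compound 4 (0.48 log units; beyond the scatter). Compound 4 is therefore estimated at 3 nM, within a range from 1 nM to 10 nM.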

Compound 4, half-maximal inhibitory concentration: 1 nM
Estimate against measurement, compound 4: 3.0-fold (0.48 log units) above, within the range that was stated.
By their numbers in this assay, from the lowest: compounds 1 and 4 (each within the scatter of the next); then compound 3; then compound 2.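

In this assay, no change at the digits printed from compound 1 to compound 4 (within the scatter) shows that chloro and cyano read alike on this aromatic carbon, although cyano is larger by a heavy atom and adds a hydrogen-bond acceptor. Among the compounds shown here, the earlier steps, such as a 20-fold higher number from compound 1 to compound 2 (1.30 log units; beyond the scatter), all changed the oxygen-containing ring, so this is the first sign that the position para to the large group can take a different substituent without a measurable change. No available evidence explains why the two groups read alike. On these data alone, whether an amine or a carboxylic acid would also read alike here remains open. So does whether cyano in place of chloro would give the same result on compound 2 or compound 3.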